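A few compounds are considered here, and "the series" means these few. Any claim that something is new, unique, unknown or untested is made for them only; others in the source may bear on it.

Measured so far:

Compound 1, `O=[N+]([O-])c1cccc2c1CN(c1ncnc3c1nc1n3[C@@H]3O[C@H](CO1)[C@@H](O)[C@H]3O)CC2`, gives 1740000 nM in an assay on isolated protein for binding affinity to Equilibrative nucleoside transporter 1 (Homo sapiens); on this read-out higher numbers stand for weaker inhibition and lower numbers for stronger inhibition.
Compound 2, `Nc1nc(SCc2cccc(Br)c2)c2ncn([C@@H]3O[C@H](CO)[C@@H](O)[C@H]3O)c2n1`, gives 2880 nM in this assay.
Compound 3, `CCCCn1cnc2c(SC(C)C)nc(N)nc21`, gives 120000 nM in this assay.

Among these three, compound 2 has the lowest number in this assay, and so the strongest inhibition. Its nearest neighbour is compound 3, whose number is far higher, well beyond the usual scatter, and compound 1 lies further still, also beyond the scatter. Compound 2 therefore stands clearly apart as the most potent of the three.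

The next compound to consider is compound 4, `Cc1cccc(CSc2nc(N)nc3c2ncn3[C@@H]2O[C@H](CO)[C@@H](O)[C@H]2O)n1`. It differs from compound 2 in one place:

6-methylpyridin-2-yl in place of 3-bromophenyl on a saturated chain carbon bound to a sulfur

Within the data shown here, no pair of measured compounds shows this kind of change, so there is no measured step to lean on. The change keeps the size of the group and its attachment, trading one aromatic ring for another of the same ring size that carries a single nitrogen. With nothing measured to guide the direction, a modest weakening, or no change beyond the scatter, seems the most reasonable expectation. The step from compound 2 to compound 4 in this assay is expected to be a 2.8-fold higher number from compound 2 to compound 4 (0.44 log units; beyond the scatter). Compound 4 is therefore estimated at 8000 nM, with a range from 2000 nM to 40000 nM.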

Compound 4, half-maximal inhibitory concentration: 11500000 nM
Compound 4: the middle estimate sits 1400-fold (3.16 log units) below what was measured, and the stated range ends below it.
By their numbers in this assay, from the lowest: compound 2; then compound 3; then compound 1; then compound 4.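

In this assay replacing 3-bromophenyl with 6-methylpyridin-2-yl on a saturated chain carbon bound to a sulfur gives a 4000-fold higher number from compound 2 to compound 4 (3.60 log units; beyond the scatter) and so a large loss of inhibition. Among these compounds, both groups have 7 heavy atoms and one six-membered aromatic ring, so a matching size and ring type are clearly not enough to keep inhibition at this position, something the earlier compounds could not show since no two of them differed in only one place. No measurement shown here explains why the loss is so large.

This single step also changes several things at once: the bromine leaves, a ring nitrogen that counts as a hydrogen-bond acceptor enters, and a methyl group arrives, so the compounds shown cannot say which of these carries the loss. From the compounds shown here alone, a plain phenyl, a pyridin-2-yl without the methyl and a 3-methylphenyl at the same place would help to separate these changes, and whether a 3-chlorophenyl would keep the inhibition of compound 2 also remains open.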